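The source may hold more compounds than are shown below. What is called first, only, known or untested is meant among the compounds shown, and "the series" means these compounds.

Compound 2 `NCC1COCC(c2ccccc2)(c2ccccc2)O1` stands at the edge of what can be read in an assay on membranes from brain for displacement of a labelled ligand from Sigma non-opioid intracellular receptor 1 (Cavia porcellus), read by scintillation counting, with a stated time of 120 min, in the presence of a further agent that is not named here; on this read-out lower numbers stand for stronger inhibition and higher numbers for weaker inhibition: compound 2 gives > 10000 nM, which is a limit of the assay (the limit of > 10000 nM in this assay, at which 1 of the 2 values shown sits). Compound 1 `c1ccc(CNCC2COCC(c3ccccc3)(c3ccccc3)O2)cc1` carries a benzyl on the amine nitrogen, and in this assay compound 1 gives 4900 nM. Removing that benzyl gave an at least 2.0-fold higher number from compound 1 to compound 2 (0.30 log units; that floor lies within the scatter). Compound 3 `c1ccc(CNCCC2COCC(c3ccccc3)(c3ccccc3)O2)cc1` carries (benzylamino)methyl in place of amino on a saturated chain carbon bound to a saturated ring carbon. In compound 3 the benzyl amine returns, now on a longer chain. The step of an at least 2.0-fold higher number from compound 1 to compound 2 (0.30 log units; that floor lies within the scatter) went the other way, so binding is expected to recover. Compound 3 is therefore estimated at 4000 nM, between 1500 nM and 12000 nM, an expected step of an at least 2.5-fold lower number from compound 2 to compound 3 (0.39 log units; beyond the scatter).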

Compound 3, inhibition constant: 502 nM
Compound 3: middle estimate off by 8.0-fold (0.90 log units), on the high side; the whole stated range lies above it.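

With the benzyl kept on the nitrogen, (benzylamino)methyl in place of benzylamino gave a 9.8-fold lower number from compound 1 to compound 3 (0.99 log units; beyond the scatter), so at this position the length of the chain counts, not only the presence of the benzyl. The change of chain and benzyl together gave an at least 19-fold lower number from compound 2 to compound 3 (1.29 log units; beyond the scatter). That size is only a floor because compound 2 stands at a limit of the assay: the limit of > 10000 nM in this assay, at which 1 of the 3 values shown sits.

Still open, as far as these compounds go, is whether a longer chain would lower the number further. Also open, from the compounds shown here alone, is whether aminomethyl, with no benzyl on its nitrogen, would keep any of the gain on this chain.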